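This account rests on a few compounds, and the source may have more. Where it says the series, first, only, none or still open, it means among the compounds named here.

Compound 3 `CC(C)C[C@H](N)c1cc(C(F)(F)F)ccc1N1CCN(C(=O)COc2cccc(Cl)c2)CC1` stands second highest of the three numbers in an assay on HEK293 cells for displacement of a labelled ligand from Melanocortin receptor 4 (Homo sapiens) (a higher number here means a weaker inhibitor, a lower number a stronger inhibitor), where compound 3 gives 2600 nM. Compound 2 `CC(C)C[C@H](N)c1cc(C(F)(F)F)ccc1N1CCN(C(=O)COc2ccc([N+](=O)[O-])cc2)CC1` gives 3100 nM, and a 1.2-fold lower number from compound 2 to compound 3 (0.08 log units; within the scatter). Compound 1 `COc1cc(CC(C)C(=O)N2CCN(c3ccc(C(F)(F)F)cc3[C@@H](N)CC(C)C)CC2)ccc1Cl` gives 230 nM and lies furthest from compound 3, since an 11-fold higher number from compound 1 to compound 3 (1.05 log units; beyond the scatter). Compound 4 `CCOc1cccc(CC(C)C(=O)N2CCN(c3ccc(C(F)(F)F)cc3[C@@H](N)CC(C)C)CC2)c1` is not yet measured in this assay; it differs from compound 3 by 1-(3-ethoxybenzyl)ethyl in place of (3-chlorophenoxy)methyl on a carbonyl carbon. Within the data shown here, the 1-(3-ethoxybenzyl)ethyl group is of the same type as the group on the carbonyl carbon of compound 1, so the steps that bear on the change are an 11-fold higher number from compound 1 to compound 3 (1.05 log units; beyond the scatter) and a 13-fold higher number from compound 1 to compound 2 (1.13 log units; beyond the scatter), both large and running opposite to the present direction. A large step to a lower number in this assay is therefore expected, a 7.4-fold lower number from compound 3 to compound 4 (0.87 log units; beyond the scatter). Compound 4 is estimated at 350 nM, in the range 120 nM to 1100 nM.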

Compound 4, inhibition constant: 2200 nM
The estimate for compound 4 lay 6.3-fold (0.80 log units) below the measured number, and the stated range ends below it.
By their numbers in this assay, from the lowest: compound 1; then compounds 4, 3 and 2 (each within the scatter of the next).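

The 1-(3-ethoxybenzyl)ethyl group does not by itself bring the number down to that of compound 1: replacing (3-chlorophenoxy)methyl gives a 1.2-fold lower number from compound 3 to compound 4 (0.07 log units; within the scatter), and replacing (4-nitrophenoxy)methyl gives a 1.4-fold lower number from compound 2 to compound 4 (0.15 log units; within the scatter). The difference instead appears with the ring substituents on the branched chain, where 3-ethoxyphenyl in place of 4-chloro-3-methoxyphenyl gives a 9.6-fold higher number from compound 1 to compound 4 (0.98 log units; beyond the scatter). No measurement shown explains this.

Still open, on these data alone, is which part of the 4-chloro-3-methoxyphenyl group carries this step, since it differs from 3-ethoxyphenyl in both substituents. 3-Methoxyphenyl and 4-chloro-3-ethoxyphenyl groups on the same chain would separate the two.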